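The compounds below may be only part of what the source reports. "The series", "measured", "known", "first", "only" and "open" are said of these compounds alone.

Three measured compounds share a core built around a carbonyl-bearing chain attached to a saturated nitrogen ring that carries an aryl group. Compound 1 `N#Cc1ccc(N2CC[C@H](NCCC(=O)c3csc4ccccc34)C2)cc1` carries a nitrile on its aryl ring. In an assay on HEK293 cells for displacement of a labelled ligand from 5-hydroxytryptamine receptor 7 (Homo sapiens), read by scintillation counting, with a stated time of 1 h (a higher number here means a weaker inhibitor, a lower number a stronger inhibitor), compound 1 is reported only as a limit, > 100000 nM. Compound 2 `O=C(CCN[C@@H]1CCN(c2ccc([N+](=O)[O-])cc2)C1)c1csc2ccccc12` carries a nitro group instead. In this assay compound 2 is likewise reported only as a limit, > 100000 nM. Compound 3 `O=C(CCN1CCCN(c2ccc([N+](=O)[O-])cc2C(F)(F)F)CC1)c1csc2ccccc12` adds a trifluoromethyl group and a larger saturated ring. In this assay compound 3 also gives only a limit, > 100000 nM. So compound 2 stands where every measured value stands: at the limit, with no number to compare, since (the limit of > 100000 nM in this assay, at which 3 of the 3 values shown sit). Compound 4 `O=C(CCN[C@H]1CCN(c2ccc([N+](=O)[O-])cc2)C1)c1csc2ccccc12` is not yet measured; it differs from compound 2 as follows: the two compounds have the same atoms and bonds and differ only in configuration as drawn: 1 of 1 stereo elements differ; a stereocentre at a saturated ring carbon is drawn R in compound 2 and S in compound 4. Going by the values given here, no measured pair shows how such a change in configuration shifts the inhibition constant. A step of no clear size is expected, and compound 4 is estimated at 100000 nM, within 5000 nM to 300000 nM, the expected step from compound 2 being a number no higher from compound 2 to compound 4 (the limit leaves the size open).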

Compound 4, inhibition constant: > 100000 nM
Compound 4 gave a limit, no number; the forecaster's own chance of this, stated with the estimate: 70%; the middle value sits exactly at the limit.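

No step can be read from compound 2 to compound 4 or from compound 1 to compound 4, since all of these results are limits rather than numbers: the limit of > 100000 nM in this assay, at which 4 of the 4 values shown sit.

The compounds shown leave open whether configuration, or nitro in place of cyano, changes the inhibition constant at all.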